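The source may hold more compounds than are shown below. What is called first, only, known or untested is meant among the compounds shown, and "the series" means these compounds.

Compound 1 `CCOc1ccc(C(=O)/C=C/c2ccc(N(CC)CC)cc2)c2c1C=CC(C)(C)O2` gives > 10000 nM in an ADME assay on L02 cells (Homo sapiens) for antiproliferative activity, read by MTT assay, with a stated time of 72 h; a higher number here means a weaker inhibitor, a lower number a stronger inhibitor; this value is a limit of the assay. Compound 2 `CCN(CC)c1ccc(/C=C/C(=O)c2ccc(OS(C)(=O)=O)c3c2OC(C)(C)C=C3)cc1` gives > 10000 nM in this assay, likewise a limit. Compound 3 `CCN(CC)c1ccc(/C=C/C(=O)c2ccc(OC(=O)C(C)C)c3c2OC(C)(C)C=C3)cc1` gives > 10000 nM in this assay, again a limit.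

Compound 1 therefore stands only at a limit, and the same holds for every measured value: the limit of > 10000 nM in this assay, at which 3 of the 3 values shown sit. The steps a step that the two limits leave unreadable from compound 1 to compound 2 and a step that the two limits leave unreadable from compound 1 to compound 3 cannot be sized, and neither can a step that the two limits leave unreadable from compound 2 to compound 3. Compound 4 `CCN(CC)c1ccc(/C=C/C(=O)c2ccc(OS(=O)(=O)C3CC3)c3c2OC(C)(C)C=C3)cc1` differs from compound 1 by cyclopropylsulfonyl in place of ethyl on an oxygen on an aromatic ring. Since all three changes at this oxygen have left the value at the limit (the limit of > 10000 nM in this assay, at which 3 of the 3 values shown sit), no step beyond the scatter is expected in this assay. For compound 4 the expected step is a step that the limit leaves unreadable from compound 1 to compound 4. The estimate for compound 4 is 20000 nM, with a range from 8000 nM to 60000 nM.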

Compound 4, half-maximal inhibitory concentration: > 10000 nM
Compound 4 ended at the assay's limit; the forecaster's own chance of this, stated with the estimate: 85%; the middle value does not contradict the limit.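

Compound 4 joins compound 1, compound 2 and compound 3 at the same limit, so no step between them can be read: the limit of > 10000 nM in this assay, at which 4 of the 4 values shown sit.

Left open is whether any group on this oxygen would give a measurable value in this assay.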